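The source may report more compounds than this note shows. Statements on the series, on what has been measured and on what is new or still open speak of the compounds shown alone.

Working notes on the series. The shared core is seen in compound 1 `COc1ccc(S(=O)(=O)Oc2ccccc2/C=C(\C#N)C(=O)Nc2nnc(-c3cccs3)s2)cc1`, compound 2 `N#C/C(=C\c1ccccc1OS(=O)(=O)c1ccc([N+](=O)[O-])cc1)C(=O)Nc1nnc(-c2cccs2)s1` and compound 3 `COc1ccc(Cc2nnc(NC(=O)/C(C#N)=C/c3ccccc3OS(=O)(=O)c3ccc([N+](=O)[O-])cc3)s2)cc1`, all tested in a functional assay on HL-60 cells (Homo sapiens) for inhibition, read by CCK-8 assay, with a stated time of 48 h, tested at 20 uM; a higher number here means more inhibition of growth at the concentration tested, a lower number less inhibition of growth. Compound 1 gives 67%, compound 2 gives 23%, and compound 3 gives 51%, which is the second highest of the three numbers; compound 3 sits beyond the scatter on both sides, with compound 1 higher and compound 2 lower.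

The step to compound 4 `COc1ccc(Cc2nnc(NC(=O)/C(C#N)=C/c3ccccc3OS(=O)(=O)c3ccc(F)cc3)s2)cc1` is the change (fluoro in place of nitro on an aromatic carbon). Within the data shown here, the only measured step at this position is a number 44 percentage points lower from compound 1 to compound 2 (beyond the scatter), where the nitro group entered. Among the measured compounds shown here, its removal in compound 4 therefore points toward a higher number, though fluoro is not methoxy and no measured pair tells how much of that step returns. The step of a number 28 percentage points higher from compound 2 to compound 3 (beyond the scatter) touches a different part of the core and is not taken as bearing on this change.

A rise is expected for compound 4 in this assay, and the step is estimated as a number 13 percentage points higher from compound 3 to compound 4 (beyond the scatter). The estimate for compound 4 is 64%, within a range of 42% to 84%.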

Compound 4, percent growth inhibition at one concentration: 25%
For compound 4 the middle estimate is 39 percentage points above the measured one; measured number outside the range, below it.
By their numbers in this assay, from the lowest: compounds 2 and 4 (each within the scatter of the next); then compound 3; then compound 1.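

In this assay the change from nitro to fluoro gives a number 26 percentage points lower from compound 3 to compound 4 (beyond the scatter), so with 4-methoxybenzyl on the core, taking out the nitro group does not raise the number. Set against a number 44 percentage points lower from compound 1 to compound 2 (beyond the scatter), where nitro replaced methoxy with thiophen-2-yl on the core, nitro goes with a lower number in one pair and a higher number in the other, and no single ordering of groups at this position holds across both pairs. No evidence on hand accounts for this difference between the two steps.

Still open, as far as these compounds go, is how methoxy and fluoro compare at this position with the rest of the core held fixed. Also open, from the compounds shown here alone, is how an amino group or a carboxylic acid in place of nitro would read on either core.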